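Chalcone series: hydroxy to methyl on the aryl ring

The source may report more compounds than this note shows. Statements on the series, on what has been measured and on what is new or still open speak of the compounds shown alone.

Measured so far in a functional assay on A549 cells (Homo sapiens) for inhibition, read by MTT assay, with a stated time of 72 h; on this read-out lower numbers stand for stronger inhibition and higher numbers for weaker inhibition:
- compound 1 `COc1cc(/C=C/C(=O)c2c(O)cc(O)cc2OC)cc(OC)c1OC` gives 28400 nM
- compound 2 `COc1cc(OC)c(C(=O)/C=C/c2ccc(O)cc2)c(OC)c1` gives 49400 nM

Compound 2 has the higher of the two numbers shown, but its gap to compound 1 lies within the usual scatter, so the two cannot be separated on this assay. Compound 3 `COc1cc(OC)c(C(=O)/C=C/c2ccc(C)cc2)c(OC)c1` differs from compound 2 as follows: methyl in place of hydroxy on an aromatic carbon. For the measured compounds named here, no measured pair covers this change, so there is no step to lean on. The expectation is a shift of a 1.2-fold lower number from compound 2 to compound 3 (0.09 log units; within the scatter), none beyond the scatter, since both measured numbers sit close together. Compound 3 is estimated at 40000 nM, with a range of 12000 nM to 130000 nM.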

Compound 3, half-maximal inhibitory concentration: 15000 nM
For compound 3 the middle estimate is 2.7-fold (0.43 log units) above the measured one; measured number inside the range.
By their numbers in this assay, from the lowest: compounds 3, 1 and 2 (each within the scatter of the next, the first and the last beyond it).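

In this assay, methyl in place of hydroxy on an aromatic carbon para to a large group gives a 3.3-fold lower number from compound 2 to compound 3 (0.52 log units; beyond the scatter), so this position responds to the group it carries. The change removes a hydrogen-bond donor and a hydrogen-bond acceptor, and the number still falls, though this one pair cannot show which feature matters. No measurement at hand accounts for the step.

Still open, as far as these compounds go, is how an amine, a carboxylic acid or a longer chain such as ethyl would read at this position, and whether the step holds on other cores.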